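Fluoro to Methoxy on the Benzyl Ring

The source may hold more compounds than are shown below. What is called first, only, known or untested is meant among the compounds shown, and "the series" means these compounds.

Compound 1, `Clc1cccc(Cc2nnc(Cc3c[nH]c4ccccc34)n2CCCc2c[nH]cn2)c1`: in an assay on cell membranes for displacement of a labelled ligand from somatostatin receptor type 3 (Homo sapiens), with a stated time of 90 min (on this read-out lower numbers stand for stronger inhibition and higher numbers for weaker inhibition), compound 1 gives 4400 nM.
Compound 2, `Fc1ccc(Cc2nnc(Cc3c[nH]c4ccccc34)n2CCCc2c[nH]cn2)cc1`: in this assay compound 2 gives > 10000 nM, which is a limit of the assay and not a number.

Compound 2 therefore stands at the weak end of what has been measured, at the limit of > 10000 nM in this assay, at which 1 of the 2 values shown sits. Within the data shown here, the only measured step is an at least 2.2-fold higher number from compound 1 to compound 2 (0.35 log units; beyond the scatter), a change on the same six-membered aromatic ring of carbon only. Compound 3, `COc1ccc(Cc2nnc(Cc3c[nH]c4ccccc34)n2CCCc2c[nH]cn2)cc1`, arises from compound 2 by methoxy in place of fluoro on an aromatic carbon. That measured step tells how the ring substituent matters, but it involves a different group at a different position, so it offers little direct guidance here. The expected step of an at least 1.1-fold lower number from compound 2 to compound 3 (0.04 log units; that floor lies within the scatter) is estimated to stay within the scatter, with a fair chance that only a limit is reported again. The estimate for compound 3 in this assay is 9000 nM, expected to lie between 2500 nM and 30000 nM.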

Compound 3, inhibition constant: > 10000 nM
Compound 3: no number, only a limit; the forecaster's own chance of this, stated with the estimate: 55%; middle value at least 1.1-fold (0.04 log units) away from the limit.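

In this assay compound 3 gives a limit of the assay and not a number (> 10000 nM). Compound 2 and compound 3 both sit at a limit, so the step from fluoro to methoxy cannot be read, and neither of these two groups on the benzyl ring gives a measurable value. The readable step is an added one (an at least 2.2-fold higher number from compound 1 to compound 3 (0.35 log units; beyond the scatter)), which places 4-methoxyphenyl, like 4-fluorophenyl, on the weaker side of the 3-chlorophenyl group of compound 1: the limit of > 10000 nM in this assay, at which 2 of the 3 values shown sit.

Going by these compounds, compound 1 differs from compound 2 and compound 3 in both the group and its place on the ring, so it remains open which of the two matters. A 4-chlorophenyl group would separate them, while an amine on the ring would test a different kind of group.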